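From Trifluoromethyl to Cyano: an Untested Step

The source may report more compounds than this note shows. Statements on the series, on what has been measured and on what is new or still open speak of the compounds shown alone.

Within the data shown here, compound 2 `Oc1cc(C(F)(F)F)ccc1-c1nc(-c2ccccc2O)n(-c2ccc(C(F)(F)F)cc2)n1` stands highest of the two numbers so far in a functional assay on PC-12 cells (Rattus norvegicus) for cytotoxicity, read by MTT assay, with stated times of 2 h and 24 h, tested at 5 uM (a lower number here means a weaker effect, a higher number a stronger effect of the compound at the concentration tested), where compound 2 gives 90.5%. Among the measured compounds shown here, its only neighbour, compound 1 `Oc1cc(C(F)(F)F)ccc1-c1nc(-c2ccccc2O)n(-c2ccc(Cl)cc2)n1`, gives 87.3% in this assay, and the step of a number 3.2 percentage points higher from compound 1 to compound 2 (within the scatter) lies within the scatter, so the two compounds cannot be ordered. Compound 3 `N#Cc1ccc(-n2nc(-c3ccc(C(F)(F)F)cc3O)nc2-c2ccccc2O)cc1` has not yet been measured. It differs from compound 2 by cyano in place of trifluoromethyl on an aromatic carbon. For the measured compounds named here, the one measured step, from compound 1 to compound 2, exchanged groups at this same place and moved the read-out by a number 3.2 percentage points higher from compound 1 to compound 2 (within the scatter), which is no movement beyond the scatter. On that basis the change to compound 3 is expected to bring a step of a number 3.5 percentage points lower from compound 2 to compound 3 (within the scatter) in this assay, that is, none beyond the scatter. Compound 3 is therefore estimated at 87%, with a range from 77% to 96%.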

Compound 3, a percentage reported as activity, at one concentration (the size of the read-out at that concentration, not a potency): 86.8%
Compound 3: the middle estimate sits 0.2 percentage points above what was measured, and the stated range covers the measured number.
By their numbers in this assay, from the lowest: compounds 3, 1 and 2 (each within the scatter of the next).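

In this assay, replacing trifluoromethyl with cyano brings a number 3.7 percentage points lower from compound 2 to compound 3 (within the scatter), and replacing chloro with cyano brings a number 0.5 percentage points lower from compound 1 to compound 3 (within the scatter). The position on an aromatic carbon para to a large group has now carried three different groups without any step leaving the scatter, and this holds even though cyano, unlike trifluoromethyl, counts one hydrogen-bond acceptor. Nothing measured here offers an explanation for the read-out at this position.

On these data alone, whether an amine, a carboxylic acid or a longer chain at this position would move the read-out beyond the scatter remains open. Also open, as far as these compounds go, are changes elsewhere on the shared core and how these compounds would compare at other concentrations, as the read-out here comes from a single concentration.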